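The source may hold more compounds than are shown below. What is called first, only, known or untested is meant among the compounds shown, and "the series" means these compounds.

In an assay on isolated protein for agonist activity at prostaglandin E2 receptor EP2 subtype (Homo sapiens) (on this read-out lower numbers stand for an effect already at smaller amounts and higher numbers for an effect only at larger amounts of compound), compound 3 `CC(C)(CCCCF)[C@H](O)/C=C/[C@H]1COC(=O)N1CCSc1nc(C(=O)O)cs1` gives 5.7 nM. Among the three measured compounds it stands second highest: its nearest neighbour is compound 1 `CCCCC1([C@H](O)/C=C/[C@H]2COC(=O)N2CCSc2nc(C(=O)O)cs2)CCC1`, which in this assay gives 2.9 nM, a difference within the scatter, and its furthest is compound 2 `CC(C)(C)CCC1([C@H](O)/C=C/[C@H]2COC(=O)N2CCSc2nc(C(=O)O)cs2)CCC1`, which gives 3700 nM.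

Compound 4 `O=C(O)c1csc(SCCN2C(=O)OC[C@@H]2/C=C/[C@@H](O)C2(CCCCF)CCC2)n1` differs from compound 3 by 1-(4-fluorobutyl)cyclobutyl in place of 5-fluoro-1,1-dimethylpentyl on a saturated chain carbon bound to a double-bonded chain carbon and an oxygen on a saturated carbon. Within the data shown here, two measured steps bear on this. The step of a 2.0-fold higher number from compound 1 to compound 3 (0.29 log units; within the scatter) shows that swapping a butylcyclobutyl for a gem-dimethyl chain carrying a terminal fluorine changes little. The step of a 1300-fold higher number from compound 1 to compound 2 (3.11 log units; beyond the scatter), by contrast, shows how strongly an enlarged chain end can raise the number, and a 650-fold lower number from compound 2 to compound 3 (2.81 log units; beyond the scatter) returns that loss. Compound 4 keeps the chain end of compound 3, with fluorine, and only reintroduces the four-membered ring, so in this assay the change is expected to be a 1.6-fold lower number from compound 3 to compound 4 (0.21 log units; within the scatter), not beyond the scatter. Compound 4 is therefore estimated at 3.5 nM, with a range from 1.2 nM to 12 nM.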

Compound 4, half-maximal effective concentration: 2.9 nM
Beside the measured number, compound 4's estimate is 1.2-fold (0.08 log units) above it, and the stated range covers the measured number.
By their numbers in this assay, from the lowest: compounds 1, 4 and 3 (each within the scatter of the next); then compound 2.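

In this assay the terminal fluorine can now be read on its own on the cyclobutyl chain: there is no change at the digits printed from compound 1 to compound 4 (within the scatter) for fluoro in place of hydrogen on a saturated chain carbon, four bonds along the chain from a saturated ring carbon, and a 2.0-fold lower number from compound 3 to compound 4 (0.29 log units; within the scatter) for 1-(4-fluorobutyl)cyclobutyl in place of 5-fluoro-1,1-dimethylpentyl, so neither change moves the number beyond the scatter. The large loss stays with the tert-butyl chain end of compound 2, as a 1300-fold lower number from compound 2 to compound 4 (3.11 log units; beyond the scatter) with 2-fluoroethyl in place of tert-butyl shows on the same chain. Nothing given here accounts for these steps.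

As far as these compounds go, whether a hydroxyl or trifluoromethyl group at the chain end would keep the number of compound 4 stays open. So does the effect of a cyclopentyl ring in place of the four-membered ring.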